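This account rests on a few compounds, and the source may have more. Where it says the series, first, only, none or still open, it means among the compounds named here.

Of the compounds shown here, two have so far been tested in a functional assay on the whole organism with Rattus norvegicus as the target, in the glucose tolerance test; on this read-out higher numbers stand for an effect only at larger amounts of compound and lower numbers for an effect already at smaller amounts. Compound 1, `CCCCCCCCCCCCCCC1(C(=O)NCCO)CO1`, gives 100 mg/kg in this assay, and compound 2, `CCCCCCCCCCCCCCC1(C(=O)OCC(O)CO)CO1`, gives 5 mg/kg. Among the measured compounds shown here, compound 2 therefore stands at the lowest number of the two, and the only measured step, a 20-fold lower number from compound 1 to compound 2 (1.30 log units; beyond the scatter), is that one large change. Compound 3, `CCCCCCCCCCCCCCC1(C(=O)OCCCC)CO1`, is the next compound to be measured. It differs from compound 2 by propyl in place of 1,2-dihydroxyethyl on a saturated chain carbon bound to an oxygen next to a carbonyl group. For the measured compounds named here, no measured step touches exactly this part of compound 2; the step from compound 1 to compound 2 exchanged the whole group on the carbonyl carbon and was a change of a different kind. What it does show is that the group carried by the carbonyl carbon can move the result a great deal. The expectation for compound 3 is therefore uncertain, and because a 20-fold lower number from compound 1 to compound 2 (1.30 log units; beyond the scatter) was so large, a step of a 4.0-fold higher number from compound 2 to compound 3 (0.60 log units; beyond the scatter) toward a higher number is expected. Compound 3 is estimated at 20 mg/kg in this assay, with a range from 5 mg/kg to 100 mg/kg.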

Compound 3, minimum effective dose: 1.5 mg/kg
Compound 3: middle estimate off by 13-fold (1.12 log units), on the high side, and the stated range ends above it.
By their numbers in this assay, from the lowest: compound 3; then compound 2; then compound 1.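

On this position, the hydroxyl-bearing end of the group is not required for an effect at low doses in this assay: propyl in place of 1,2-dihydroxyethyl, on a saturated chain carbon bound to an oxygen next to a carbonyl group, gives a 3.3-fold lower number from compound 2 to compound 3 (0.52 log units; beyond the scatter). Among the compounds shown here, the entering propyl has no hydrogen-bond donors or acceptors, yet the number moved down rather than up, which is the one direction the earlier step could not have indicated for this particular change. Butoxy in place of (2-hydroxyethyl)amino on the carbonyl carbon gives a 67-fold lower number from compound 1 to compound 3 (1.82 log units; beyond the scatter), so this group can shift the dose needed over a wide span, though no measurement here says why either step occurs.

The compounds shown leave open whether the number would keep falling with a longer chain such as hexyl, or rise again with a shorter one such as methyl, and what an amine or a carboxylic acid at the end of the chain would do. They also leave open how much of the large step belongs to the linking atom, which a butylamino group on the carbonyl carbon could help to separate from the change in the chain.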